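This account rests on a few compounds, and the source may have more. Where it says the series, first, only, none or still open, it means among the compounds named here.

Compound 1 `CC(C(=O)NCc1ccc(C(F)(F)F)cc1N1CCC(Cc2ccccc2)(N(C)C)CC1)c1ccc(NS(C)(=O)=O)c(F)c1`: 3.79 nM
Compound 2 `CN(C)C1(Cc2ccccc2)CCN(c2cc(C(F)(F)F)ccc2CNC(=O)Nc2ccc(NS(C)(=O)=O)c(F)c2)CC1`: 1160 nM

In an assay on CHO cells for displacement of a labelled ligand from transient receptor potential cation channel subfamily V member 1 (Homo sapiens), read by scintillation counting, with a stated time of 60 min (a higher number here means a weaker inhibitor, a lower number a stronger inhibitor), compound 1 gives 3.79 nM, while compound 2 gives 1160 nM, the higher of the two numbers and far beyond the scatter from compound 1. Compound 3 `CN(C)C1(Cc2ccccc2)CCN(c2cc(C(F)(F)F)ccc2CNC(=O)Nc2ccc(CNS(C)(=O)=O)c(F)c2)CC1` carries (methanesulfonamido)methyl in place of methanesulfonamido on an aromatic carbon. Among the compounds with values here, no measured pair shows this change, so its size is unknown from the data; a modest rise in this assay beyond the scatter is expected rather than a gain. Compound 3 is therefore estimated at 2500 nM in this assay, within 700 nM to 9000 nM. That estimate means an expected step of a 2.2-fold higher number from compound 2 to compound 3 (0.33 log units; beyond the scatter).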

Compound 3, inhibition constant: 16.4 nM
The estimate for compound 3 lay 150-fold (2.18 log units) above the measured number; the measured number lies below the stated range.
By their numbers in this assay, from the lowest: compound 1; then compound 3; then compound 2.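

Placing (methanesulfonamido)methyl in place of methanesulfonamido on this aromatic carbon gives a 71-fold lower number from compound 2 to compound 3 (1.85 log units; beyond the scatter) in this assay. Within the data shown here, the earlier compounds offered no pair differing only here, so this is the first sign that the place, ortho to a fluoro group, is highly sensitive to this change. Nothing measured here accounts for the step. Going by these compounds, whether an amine, a carboxylic acid or a longer chain carrying the methanesulfonamido group would do as well at this place remains open. Also open, on these data alone, is whether the same change would lower the number on the core of compound 1.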